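Benzyl to methyl on the ring amide nitrogen of compound 2

This account rests on a few compounds, and the source may have more. Where it says the series, first, only, none or still open, it means among the compounds named here.

Compound 2 `NS(=O)(=O)c1ccc(/N=C2\NC(=O)/C(=C3/C(=O)N(Cc4ccccc4)c4ccccc43)S2)cc1` sits at the limit of a functional assay on Caco-2 cells (Homo sapiens) for antiproliferative activity, read by MTT assay; on this read-out higher numbers stand for weaker inhibition and lower numbers for stronger inhibition: in this assay compound 2 gives > 200000 nM, a limit and not a number. Compound 3 `NS(=O)(=O)c1ccc(/N=C2\NC(=O)/C(=C3/C(=O)N(Cc4ccccc4)c4ccc(Cl)cc43)S2)cc1` gives 13700 nM. Compound 1 `Cc1cc(C)c2c(c1)/C(=C1/S/C(=N/c3ccc(S(N)(=O)=O)cc3)NC1=O)C(=O)N2` gives 146000 nM. Among the measured compounds shown here, the only step measured is an at least 14-fold lower number from compound 2 to compound 3 (1.16 log units; beyond the scatter), a chloro in place of hydrogen on an aromatic carbon of the fused benzene ring, and it rests on (the limit of > 200000 nM in this assay, at which 1 of the 3 values shown sits).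

Compound 4 `CN1C(=O)/C(=C2\S/C(=N/c3ccc(S(N)(=O)=O)cc3)NC2=O)c2ccccc21` differs from compound 2 by hydrogen in place of phenyl on a saturated chain carbon bound to an amide-type nitrogen in a ring; cut one bond further out, the change reads benzyl to methyl. For the measured compounds named here, no measured step touches the substituent on the ring amide nitrogen, so the step from compound 2 to compound 3 does not bear on this change. Compound 1, which carries a hydrogen on that nitrogen together with two methyl groups on the fused ring, shows that a compound without the benzyl group can still return a number, 146000 nM, rather than a limit.

With nothing directly comparable, compound 4 is expected to stay near where compound 2 stands, meaning an estimated step of an at least 1.1-fold lower number from compound 2 to compound 4 (0.04 log units; that floor lies within the scatter). Compound 4 is therefore estimated at 180000 nM, in a range from 60000 nM to 500000 nM, with a sizeable chance that this assay again reports only a limit.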

Compound 4, half-maximal inhibitory concentration: 163000 nM
For compound 4 the middle estimate is 1.1-fold (0.04 log units) above the measured one; the range from low to high includes it.
By their numbers in this assay, from the lowest: compound 3; then compounds 1 and 4 (each within the scatter of the next). At a limit, above all of these: compound 2.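

In this assay, among the compounds shown here, the first step at the ring amide nitrogen is an at least 1.2-fold lower number from compound 2 to compound 4 (0.08 log units; that floor lies within the scatter), for benzyl to methyl, with hydrogen in place of phenyl on the saturated chain carbon. This gives the position a reading of its own, separate from the chloro step on the fused benzene ring, and shows that a compound with methyl at this nitrogen and no chloro on that ring returns a number rather than a limit, though the floor of the step alone does not establish a real change. Compound 2 gives > 200000 nM, which is a limit and not a number, so the true size of the step stays unknown, and the reading of benzyl to methyl rests on this one limit: the limit of > 200000 nM in this assay, at which 1 of the 4 values shown sits.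

Open, from the compounds shown here alone, is how the ring amide nitrogen responds to other groups, such as a longer chain like n-butyl, a chain ending in an amine or one ending in a carboxylic acid. Also open, going by these compounds, is whether chloro on the fused benzene ring would lower the number as far with methyl on that nitrogen as it does with benzyl, which would show whether the two positions act independently.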